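A few compounds are considered here, and "the series" means these few. Any claim that something is new, unique, unknown or untested is made for them only; others in the source may bear on it.

Measured so far:
compound 1, `COc1ccc(-c2cc3c(OC)cc(OC)cc3n(C)c2=O)cc1` — 10000 nM
compound 2, `COC(=O)CCn1c(=O)c(-c2ccc(OC)cc2)cc2c(OC)cc(OC)cc21` — 10000 nM

In a functional assay on J82 cells (Homo sapiens) for cytotoxicity, read by colorimetric assay and MTT assay (on this read-out higher numbers stand for weaker inhibition and lower numbers for stronger inhibition), compound 1 gives 10000 nM. Compound 2 gives 10000 nM, so it stands level with compound 1 within the scatter, and the step of no change at the digits printed from compound 1 to compound 2 (within the scatter) records no change. Compound 3, `COc1ccc(-c2cc3c(OC)cc(OC)cc3n(CCC#N)c2=O)cc1`, is not yet measured. It differs from compound 2 by cyano in place of methoxycarbonyl on a saturated chain carbon, two bonds along the chain from an aromatic nitrogen. For the measured compounds named here, only one measured step exists here, and it put (methoxycarbonyl)methyl in place of hydrogen on a saturated chain carbon bound to an aromatic nitrogen while the reading stayed where it was. Going by the values given here, nothing measured bears directly on exchanging methoxycarbonyl for cyano on that chain, so the single step is the only guide. On that basis compound 3 is expected to stay at the same level, a step of no change at the digits printed from compound 2 to compound 3 (within the scatter) that amounts to none beyond the scatter. The estimate for compound 3 in this assay is 10000 nM, with a range from 5000 nM to 20000 nM.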

Compound 3, half-maximal inhibitory concentration: 10000 nM
For compound 3 middle estimate and measured number coincide at the digits printed; the range from low to high includes it.
By their numbers in this assay, from the lowest: compounds 1, 2 and 3 (each within the scatter of the next).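

In this assay, putting cyano in place of methoxycarbonyl on a saturated chain carbon, two bonds along the chain from an aromatic nitrogen, gives no change at the digits printed from compound 2 to compound 3 (within the scatter). Measured against the plain methyl compound, the 2-cyanoethyl chain gives no change at the digits printed from compound 1 to compound 3 (within the scatter), so two different groups at the end of this chain now leave the reading in the same place, where the earlier compounds had shown only one. No supporting data offer an explanation for this sameness.

The compounds shown leave open whether a different group at the chain end, such as an amine or a carboxylic acid, would shift the reading. They also leave open whether a longer chain on the same nitrogen would do so.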